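Pyridin-2-yl in Place of 4-Methoxyphenyl: An Estimate

The source may hold more compounds than are shown below. What is called first, only, known or untested is meant among the compounds shown, and "the series" means these compounds.

Of the compounds shown here, three sharing one core have been tested in a functional assay on MCF7 cells (Homo sapiens) for cytotoxicity, read by MTT assay, with a stated time of 4 days; a lower number here means a stronger inhibitor, a higher number a weaker inhibitor. Compound 1 `C=C1C[C@]23C[C@@]1(O)CC[C@H]2c1cc(Br)c(O)c(C)c1[C@@H]3Cn1cc(-c2ccc(OC)cc2)nn1` gives > 20000 nM, which is a limit of the assay rather than a number. Compound 2 `COc1ccc(-c2cn(C[C@H]3c4c(ccc(OS(=O)(=O)c5ccc(C)cc5)c4C)[C@@H]4CC[C@@]5(C)C[C@]43CC5=O)nn2)cc1` likewise gives > 20000 nM, again a limit. Among the compounds with values here, compound 3 `C=C1C(=O)[C@]23C[C@@]1(O)CC[C@H]2c1ccc(O)c(C)c1[C@@H]3Cn1cc(-c2ccc(Cl)cc2)nn1` gives 2470 nM in this assay, the only number among the three. So compound 1 stands at the weak end of what is shown, at the limit noted as the limit of > 20000 nM in this assay, at which 2 of the 3 values shown sit.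

Compound 4 `C=C1C[C@]23C[C@@]1(O)CC[C@H]2c1cc(Br)c(O)c(C)c1[C@@H]3Cn1cc(-c2ccccn2)nn1` has not yet been measured. It differs from compound 1 in one place: pyridin-2-yl in place of 4-methoxyphenyl on an aromatic carbon. Within the data shown here, no step between two measured compounds isolates this change, so nothing here says which way it should move the result.

Among the measured compounds shown here, with compound 1 at the limit and no comparable pair to lean on, compound 4 is expected to sit near the same limit, with the step from compound 1 to compound 4 estimated as a step that the limit leaves unreadable from compound 1 to compound 4, not beyond the scatter. The estimate for compound 4 is 25000 nM, within 5000 nM to 100000 nM.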

Compound 4, half-maximal inhibitory concentration: > 20000 nM
Compound 4: only a limit was reported; the forecaster's own chance of this, stated with the estimate: 65%; the middle value lies beyond the limit too.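

In this assay compound 4 gives > 20000 nM as a limit of the assay and not as a number. Within the data shown here, compound 1 also stands at a limit, so no step from compound 1 to compound 4 can be read. The compounds shown leave open whether pyridin-2-yl in place of 4-methoxyphenyl moves the result at all, and in which direction.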